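Swapping Bromo for Fluoro on a Fused Triazole Core

A few compounds are considered here, and "the series" means these few. Any claim that something is new, unique, unknown or untested is made for them only; others in the source may bear on it.

Compound 3 `Brc1cc(Br)c2nnn(CC3CC3)c2c1` gives 0.6 mL/min/g in an ADME assay on microsomes from liver (Homo sapiens) for metabolic stability, tested at 2.5 uM (on this read-out lower numbers stand for slow clearance and higher numbers for fast clearance), which is the highest of the three numbers measured, standing apart from both neighbours. Compound 1 `Fc1cc(C(F)(F)F)ccc1-c1ccc(Cn2nnc3ccccc32)cc1` gives 0.1 mL/min/g in this assay, and compound 2 `FC(F)(F)c1cc(Br)c2nnn(CC3CC3)c2c1` gives 0.1 mL/min/g. Among the compounds with values here, the only measured step between single-change neighbours runs a 6.0-fold higher number from compound 2 to compound 3 (0.78 log units; beyond the scatter), so the arrival of bromo at that carbon came with a markedly higher number.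

Compound 4 `Fc1cc(Br)c2nnn(CC3CC3)c2c1` is the next member of the series and has not yet been measured in this assay. It differs from compound 3 as follows: fluoro in place of bromo on an aromatic carbon. The change concerns the same aromatic carbon at which the measured step placed a bromo group; now that bromo group leaves and fluoro enters. Within the data shown here, no measured pair shows fluoro replacing bromo, so the direction rests on the single step from compound 2 to compound 3, in which removing the smaller group and installing bromo raised the number. Reversing the presence of bromo is therefore expected to move the number down again, toward the low values of compound 2 and compound 1, though the size is uncertain. The expected step is a 3.0-fold lower number from compound 3 to compound 4 (0.48 log units; beyond the scatter), and compound 4 is estimated at 0.2 mL/min/g, within a range from 0.07 mL/min/g to 0.6 mL/min/g.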

Compound 4, intrinsic clearance in a liver preparation (reported as CLH), per the amount of preparation that the assay uses: 0.4 mL/min/g
Compound 4: middle estimate off by 2.0-fold (0.30 log units), on the low side; the measured number falls inside the stated range.
By their numbers in this assay, from the lowest: compounds 1 and 2 (each within the scatter of the next); then compounds 4 and 3 (each within the scatter of the next).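

At this aromatic carbon, fluoro and bromo cannot be told apart in this assay, where the exchange gives a 1.5-fold lower number from compound 3 to compound 4 (0.18 log units; within the scatter). Trifluoromethyl is the group that stands apart among the three tested here, as replacing it with fluoro gives a 4.0-fold higher number from compound 2 to compound 4 (0.60 log units; beyond the scatter), a step beyond the scatter, as was the earlier step to bromo. The rise seen on leaving trifluoromethyl is therefore not specific to bromo, since it appears with both halogens in this small set, and nothing available here bears on the reason for it.

From the compounds shown here alone, it remains open whether a different group at this carbon, such as a nitrile, a methoxy group or an amine, would fall with trifluoromethyl or with the two halogens. Going by these compounds, it is also open whether the same separation would hold once the remaining bromo group is replaced.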